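Three Limits and a Fourth Compound Expected to Match

The source may hold more compounds than are shown below. What is called first, only, known or untested is meant among the compounds shown, and "the series" means these compounds.

Each measured compound was tested in a functional assay on HCT-116 cells (Homo sapiens) for cytotoxicity, with a stated time of 48 h; on this read-out higher numbers stand for weaker inhibition and lower numbers for stronger inhibition.
Compound 1, `O=[N+]([O-])c1ccc(CN2CCC(n3cc(CC(OCc4cc(-c5ccc(Br)cc5)no4)c4ccc(Br)cc4)nn3)CC2)cc1`, gives > 25000 nM, which is a limit of the assay.
Compound 2, `O=[N+]([O-])c1ccc(CN2CCC(n3cc(CC(OCc4cc(-c5ccc(F)cc5)no4)c4ccc(Br)cc4)nn3)CC2)cc1`, gives > 25000 nM, also a limit.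
Compound 3, `O=[N+]([O-])c1ccc(CN2CCC(n3cc(CC(OCc4cc(-c5ccccc5Br)no4)c4ccc(Br)cc4)nn3)CC2)cc1`, gives > 25000 nM, again a limit.

From compound 1 to compound 2 the change is fluoro in place of bromo on an aromatic carbon, and the resulting step is a step that the two limits leave unreadable from compound 1 to compound 2. The cores of compound 1 and compound 3 differ by 2-bromophenyl in place of 4-bromophenyl on an aromatic carbon. Compound 4, `O=[N+]([O-])c1ccc(CN2CCC(n3cc(CC(OCc4cc(-c5ccccc5F)no4)c4ccc(Br)cc4)nn3)CC2)cc1`, is not yet measured; it differs from compound 3 by fluoro in place of bromo on an aromatic carbon. The change is the same kind as that from compound 1 to compound 2, not the same, since the place reads "ortho to a large group" instead of "para to a large group". Because every measured value sits at the limit of > 25000 nM in this assay, at which 3 of the 3 values shown sit, compound 4 is expected to give about 40000 nM, a step that the limit leaves unreadable from compound 3 to compound 4, with a limit the most likely outcome.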

Compound 4, half-maximal inhibitory concentration: 9000 nM
For compound 4 the middle estimate is 4.4-fold (0.65 log units) above the measured one, and the stated range ends above it.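

In this assay, fluoro in place of bromo on the 2-bromophenyl group gives an at least 2.7-fold lower number from compound 3 to compound 4 (0.44 log units; beyond the scatter), and the other two comparisons give an at least 2.7-fold lower number from compound 2 to compound 4 (0.44 log units; beyond the scatter) and an at least 2.7-fold lower number from compound 1 to compound 4 (0.44 log units; beyond the scatter). The steps among compound 1, compound 2 and compound 3 cannot be read, because all three sit at a limit of the assay: the limit of > 25000 nM in this assay, at which 3 of the 4 values shown sit. So the swap is visible on one core only, ortho to a large group, and the same swap para to a large group, on the core of compound 1, shows nothing about whether the change carries over.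

The compounds shown leave open whether chloro or methoxy in that same place would match fluoro. They also leave open how an amine in place of the nitro group would affect the read-out.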